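The compounds below may be only part of what the source reports. "The series", "measured", "known", "first", "only" and "open" are said of these compounds alone.

Measured so far in a functional assay on the whole organism with Rattus norvegicus as the target; a lower number here means that less compound is needed, a higher number that more compound is needed for the effect:
Compound 1 `CCOCCOC(=O)C(=O)Nc1nc(-c2cc(Cl)no2)cs1` gives 6 mg/kg
Compound 2 `CCOCCOC(=O)C(=O)Nc1nc(-c2cc(Br)no2)cs1` gives 11 mg/kg
Compound 3 `CCOCCOC(=O)C(=O)Nc1nc(-c2cc(COC)no2)cs1` gives 2.4 mg/kg

These three compounds share one core and differ in a single group. Compound 3 has the lowest number of the three, so the least of it is needed for the effect. The steps that lead to it are modest but beyond the scatter: a 2.5-fold lower number from compound 1 to compound 3 (0.40 log units; beyond the scatter) and a 4.6-fold lower number from compound 2 to compound 3 (0.66 log units; beyond the scatter). Exchanging one halogen for the other matters less, and a 1.8-fold higher number from compound 1 to compound 2 (0.26 log units; within the scatter) cannot be told apart from repeat-measurement noise.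

Compound 4 `CCOCCOC(=O)C(=O)Nc1nc(-c2cc(C(=O)OCC)no2)cs1` changes that same group again, with ethoxycarbonyl in place of methoxymethyl on an aromatic carbon. Within the data shown here, no measured compound carries ethoxycarbonyl, so there is no direct evidence for it. Among the measured compounds shown here, the only guide is that both other groups tried at this place gave higher numbers than compound 3, and two comparisons make a thin basis. A modest move in that direction therefore seems likely in this assay, similar in size to the steps above. The expected change is a 2.1-fold higher number from compound 3 to compound 4 (0.32 log units; beyond the scatter). For compound 4 the estimated value is 5 mg/kg, with an expected range from 1.5 mg/kg to 16 mg/kg.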

Compound 4, dose for half-maximal effect: 0.08 mg/kg
Estimate against measurement, compound 4: 63-fold (1.80 log units) above; measured number below the stated range.
By their numbers in this assay, from the lowest: compound 4; then compound 3; then compounds 1 and 2 (each within the scatter of the next).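

In this assay this position on the shared core proves far more sensitive than the halogens and methoxymethyl suggested, as ethoxycarbonyl gives a 30-fold lower number from compound 3 to compound 4 (1.48 log units; beyond the scatter) and so a large step where the earlier changes gave modest ones at most. The gap to the two halogen compounds is wider still, with a 75-fold lower number from compound 1 to compound 4 (1.88 log units; beyond the scatter) for the exchange of chloro and a 140-fold lower number from compound 2 to compound 4 (2.14 log units; beyond the scatter) for the exchange of bromo, which leaves compound 4 with the lowest number of the four and well clear of all the others. Ethoxycarbonyl differs from methoxymethyl in having more heavy atoms and a double bond outside the ring, yet no measurement here links either feature to the result, and nothing at hand explains the size of the step.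

The compounds shown leave open whether the carbonyl or the ethyl part of the group carries the gain, a question that a carboxylic acid, a methoxycarbonyl group or a primary amide at the same place could help to separate. They also leave open whether a similar gain would appear with a longer chain on the ester, or whether it would survive a change elsewhere on the shared core.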